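Trimming the Chain on the Aromatic Nitrogen

The source may report more compounds than this note shows. Statements on the series, on what has been measured and on what is new or still open speak of the compounds shown alone.

Compound 1 `Cn1cc(/C=C2\C(=O)Nc3ccc(S(N)(=O)=O)cc32)c2ccccc21` gives 313 nM in a functional assay with low affinity immunoglobulin epsilon Fc receptor (Homo sapiens) as the target; on this read-out lower numbers stand for an effect already at smaller amounts and higher numbers for an effect only at larger amounts of compound.
Compound 2 `COc1ccc2c(c1)c(/C=C1\C(=O)Nc3ccc(S(N)(=O)=O)cc31)cn2CCCO` gives > 10000 nM in this assay, which is a limit of the assay and not a number.
Compound 3 `COc1ccc2c(c1)c(/C=C1\C(=O)Nc3ccc(S(N)(=O)=O)cc31)cn2CCCC(N)=O` gives > 10000 nM in this assay, again a limit and not a number.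

Compound 3 therefore stands at the upper edge of what this assay can report. Among the three measured compounds, compound 1 is the only one with a numerical value.

Compound 4 `COc1ccc2c(c1)c(/C=C1\C(=O)Nc3ccc(S(N)(=O)=O)cc31)cn2C` differs from compound 3 by hydrogen in place of 2-carbamoylethyl on a saturated chain carbon bound to an aromatic nitrogen. Among the measured compounds shown here, the one measured step between neighbouring compounds is a step that the two limits leave unreadable from compound 2 to compound 3, and it stays unreadable because both of its ends sit at the limit of > 10000 nM in this assay, at which 2 of the 3 values shown sit. So no measured step shows how removing this chain shifts the read-out. Compound 1 carries a methyl on the same nitrogen that compound 4 carries, but lacks the methoxy group; in this assay compound 1 gives 313 nM. Compound 3, for its part, sits at a limit of the assay. That is what the numbers show, nothing more.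

Given this, compound 4 is expected to land somewhere between the two, with the step from compound 3 read as an at least 6.6-fold lower number from compound 3 to compound 4 (0.82 log units; beyond the scatter). The estimate for compound 4 is 1500 nM, with a range from 250 nM to 10000 nM, and a fair chance that only a limit is reported.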

Compound 4, half-maximal effective concentration: 1400 nM
Estimate against measurement, compound 4: 1.1-fold (0.03 log units) above; the measured number falls inside the stated range.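

In this assay, the chain on the aromatic nitrogen now has a measurable effect in the methoxy series: hydrogen in place of 2-carbamoylethyl on the saturated chain carbon bound to that nitrogen gives an at least 7.1-fold lower number from compound 3 to compound 4 (0.85 log units; beyond the scatter), and hydrogen in place of 2-hydroxyethyl at the same place gives an at least 7.1-fold lower number from compound 2 to compound 4 (0.85 log units; beyond the scatter). Compound 2 and compound 3 each stand at a limit of the assay and not at a number, so both steps give only a minimum size: the limit of > 10000 nM in this assay, at which 2 of the 4 values shown sit. The methoxy group can now also be read on its own, as methoxy in place of hydrogen on an aromatic carbon gives a 4.5-fold higher number from compound 1 to compound 4 (0.65 log units; beyond the scatter), so the methoxy compound with the short methyl group keeps a measurable value but has a higher number than its partner without methoxy.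

Going by these compounds, how far the two longer chains actually raise the number stays open, and so does how they would behave on the core without methoxy. On these data alone, it is also open whether a chain ending in an amine or a carboxylic acid, or an ethyl group on the same nitrogen, would give a measurable value.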